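The source may report more compounds than this note shows. Statements on the series, on what has been measured and on what is new or still open speak of the compounds shown alone.

In an in vitro functional assay on cells for agonist activity at Bombesin receptor subtype-3 (Homo sapiens), read by luminescence and calcium flux (a lower number here means that less compound is needed, a higher number that more compound is needed for the effect), compound 3 `O=C(O)c1ccccc1-c1ccc(CCc2ncc(CC3CC3)[nH]2)cc1` gives 1000 nM. Compound 2 `O=C(O)c1ccccc1-c1ccc(CCc2ncc(Cc3ccc(F)cc3)[nH]2)cc1` gives 1600 nM, and the step of a 1.6-fold lower number from compound 2 to compound 3 (0.20 log units; within the scatter) shows the two sit within the scatter of one another. Compound 1 `COc1ccc(Cc2cnc(CCc3ccc(-c4ccccc4C(=O)O)cc3)[nH]2)cc1` gives 5360 nM, and the steps of a 5.4-fold lower number from compound 1 to compound 3 (0.73 log units; beyond the scatter) and a 3.4-fold lower number from compound 1 to compound 2 (0.53 log units; beyond the scatter) both lie beyond the scatter, so compound 1 stands apart from the other two, while compound 3 and compound 2 cannot be separated.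

Compound 4 `CC(C)(C)c1cnc(CCc2ccc(-c3ccccc3C(=O)O)cc2)[nH]1` differs from compound 3 in one place: tert-butyl in place of cyclopropylmethyl on an aromatic carbon. All three measured steps change the group on this same ring carbon, but each of them swaps an arylmethyl for another arylmethyl or for cyclopropylmethyl; none swaps one small saturated group for another of the same size. The step that comes closest is a 1.6-fold lower number from compound 2 to compound 3 (0.20 log units; within the scatter), which stayed within the scatter, whereas the steps from compound 1 were modest. On that basis the step of a 1.2-fold higher number from compound 3 to compound 4 (0.08 log units; within the scatter) is expected to stay within the scatter, with no clear direction. Compound 4 is therefore estimated to give about 1200 nM, within a range from 500 nM to 3000 nM.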

Compound 4, half-maximal effective concentration: 4330 nM
Beside the measured number, compound 4's estimate is 3.6-fold (0.56 log units) below it; measured number outside the range, above it.
By their numbers in this assay, from the lowest: compounds 3 and 2 (each within the scatter of the next); then compounds 4 and 1 (each within the scatter of the next).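

In this assay, cyclopropylmethyl and tert-butyl both have 4 heavy atoms, all carbon, and neither has a hydrogen-bond donor or acceptor, yet the change between them gives a 4.3-fold higher number from compound 3 to compound 4 (0.64 log units; beyond the scatter). This position therefore separates two small carbon groups that these counts do not distinguish, which the earlier swaps of arylmethyl or cyclopropylmethyl groups could not show. Tert-butyl also stands apart from 4-fluorobenzyl, with a 2.7-fold higher number from compound 2 to compound 4 (0.43 log units; beyond the scatter), but it cannot be separated from 4-methoxybenzyl, with a 1.2-fold lower number from compound 1 to compound 4 (0.09 log units; within the scatter), so the presence of a ring in the group does not sort the four compounds: compound 2 and compound 3 fit such a reading, while compound 1 goes against it.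

Nothing shown here gives a measured reason for these differences. Going by these compounds, it remains open whether isopropyl, a longer chain such as n-butyl, or an amine at this position would group with compound 3 or with compound 4, and whether the difference between compound 3 and compound 4 depends on the ring of the cyclopropylmethyl group or on the branching of the tert-butyl group.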